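This account rests on a few compounds, and the source may have more. Where it says the series, first, only, none or still open, it means among the compounds named here.

Compound 3, `CCCCC(=O)c1c(OC)c(Cl)c(OC)c(Cl)c1OC`, gives 23500 nM in a functional assay on the whole organism (S2 cells, strain S2) for inhibition, with Drosophila as the target, read by a luciferase reporter, with stated times of 1.5 h and 8 h (on this read-out higher numbers stand for weaker inhibition and lower numbers for stronger inhibition), and its number sits within the usual scatter of its two companions. Compound 1, `CCCCCCCC(=O)c1c(OC)c(Cl)c(OC)c(Cl)c1OC`, gives 15300 nM, and compound 2, `CCCC(=O)c1c(OC)c(Cl)c(OC)c(Cl)c1OC`, gives 20800 nM. The steps among these three are all small: a 1.4-fold higher number from compound 1 to compound 2 (0.13 log units; within the scatter), a 1.5-fold higher number from compound 1 to compound 3 (0.19 log units; within the scatter) and a 1.1-fold higher number from compound 2 to compound 3 (0.05 log units; within the scatter). Compound 4, `CCCCCCC(=O)c1c(OC)c(Cl)c(OC)c(Cl)c1OC`, differs from compound 3 by ethyl in place of hydrogen on a saturated chain carbon, four bonds along the chain from a carbonyl carbon. Because a change of chain length gave only a 1.5-fold higher number from compound 1 to compound 3 (0.19 log units; within the scatter), no step beyond the scatter is expected here, and compound 4 is expected to land near the others, with an estimated step of a 1.3-fold lower number from compound 3 to compound 4 (0.12 log units; within the scatter). Compound 4 is therefore estimated at 18000 nM, in a range from 10000 nM to 32000 nM.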

Compound 4, half-maximal inhibitory concentration: 16800 nM
For compound 4 the middle estimate is 1.1-fold (0.03 log units) above the measured one; measured number inside the range.
By their numbers in this assay, from the lowest: compounds 1, 4, 2 and 3 (each within the scatter of the next).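

The change of ethyl in place of hydrogen on this saturated chain carbon gives a 1.4-fold lower number from compound 3 to compound 4 (0.15 log units; within the scatter) in this assay, and the other two chains give a 1.2-fold lower number from compound 2 to compound 4 (0.09 log units; within the scatter) and a 1.1-fold higher number from compound 1 to compound 4 (0.04 log units; within the scatter), so no chain shown stands beyond the scatter of another. One change of chain reads alike on two cores: the same change on two cores in this assay, a 1.5-fold higher number (0.19 log units; within the scatter) from compound 1 to compound 3 and a 1.2-fold higher number (0.09 log units; within the scatter) from compound 4 to compound 2, 1.2-fold (0.09 log units) apart, within the scatter of two such steps A second change does so too: the same change on two cores in this assay, a 1.1-fold higher number (0.05 log units; within the scatter) from compound 2 to compound 3 and a 1.1-fold lower number (0.04 log units; within the scatter) from compound 4 to compound 1, 1.2-fold (0.09 log units) apart, within the scatter of two such steps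

On these data alone, whether a longer chain would give a step beyond the scatter stays open. So does the effect of an amine or a carboxylic acid at this position.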